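Compound 4: a five-membered non-aromatic ring enters the amine side

The compounds below may be only part of what the source reports. "The series", "measured", "known", "first", "only" and "open" are said of these compounds alone.

Of the compounds shown here, three sharing one core have been measured in a functional assay on K562 cells (Homo sapiens) for inhibition, read by trypan blue exclusion, with a stated time of 72 h; a lower number here means a stronger inhibitor, a higher number a weaker inhibitor. Compound 1 `Cn1c(=O)c(S(=O)(=O)c2ccc(F)cc2F)cc2cnc(Nc3ccc4occc4c3)nc21` gives 15000 nM. Compound 2 `Cn1c(=O)c(S(=O)(=O)c2ccc(F)cc2F)cc2cnc(Nc3ccc4[nH]c(C(=O)O)cc4c3)nc21`, with 2-carboxy-1H-indol-5-yl in place of 1-benzofuran-5-yl on a nitrogen on an aromatic ring, gives 10000 nM; the step of a 1.5-fold lower number from compound 1 to compound 2 (0.18 log units; within the scatter) lies within the scatter. Compound 3 `Cc1cc2cc(Nc3ncc4cc(S(=O)(=O)c5ccc(F)cc5F)c(=O)n(C)c4n3)ccc2[nH]1` gives 750 nM, the lowest number of the three: the steps of a 20-fold lower number from compound 1 to compound 3 (1.30 log units; beyond the scatter) and a 13-fold lower number from compound 2 to compound 3 (1.12 log units; beyond the scatter) are both beyond the scatter, so compound 3 stands clearly apart from the other two.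

Compound 4 `Cn1c(=O)c(S(=O)(=O)c2ccc(F)cc2F)cc2cnc(Nc3ccc4c(c3)CC(=O)N4)nc21` has not yet been measured in this assay. It differs from compound 3 by a group of 10 heavy atoms (8 carbon, 1 nitrogen, 1 oxygen; one five-membered non-aromatic ring with 1 hetero atom, one six-membered aromatic ring of carbon only) in place of a group of 10 heavy atoms (9 carbon, 1 nitrogen; one five-membered aromatic ring with 1 hetero atom, one six-membered aromatic ring of carbon only), on a nitrogen on an aromatic ring. Both large steps seen so far are at this same place. Compound 3 carries the methyl-bearing group and has the low number; compound 2 carries the carboxy-bearing group and stays near compound 1. Compound 4 keeps one hydrogen-bond donor, as compound 3 does, but gains a hydrogen-bond acceptor, as compound 2 has. An upward step beyond the scatter, smaller than the gap to compound 2, is therefore expected. The estimated step is a 4.0-fold higher number from compound 3 to compound 4 (0.60 log units; beyond the scatter). Compound 4 is estimated at 3000 nM, within the range 800 nM to 12000 nM.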

Compound 4, half-maximal inhibitory concentration: 15000 nM
Compound 4: middle estimate off by 5.0-fold (0.70 log units), on the low side; measured number above the stated range.
By their numbers in this assay, from the lowest: compound 3; then compounds 2, 1 and 4 (each within the scatter of the next).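

In this assay, the step of a 20-fold higher number from compound 3 to compound 4 (1.30 log units; beyond the scatter) shows that the low number of compound 3 is lost even though the entering group has the same count of heavy atoms and of hydrogen-bond donors as the 2-methyl-1H-indol-5-yl group it replaces. Among the compounds shown here, with a 1.5-fold higher number from compound 2 to compound 4 (0.18 log units; within the scatter) and no change at the digits printed from compound 1 to compound 4 (within the scatter), both within the scatter, compound 4 joins compounds 1 and 2 as a third group on this nitrogen that gives no separation from the others, leaving 2-methyl-1H-indol-5-yl as the only group of the four that stands apart. No measurement among those given here accounts for this result.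

The compounds shown leave open whether the low number of compound 3 rests on the methyl itself or on the five-membered aromatic ring, a question that a plain 1H-indol-5-yl group, with hydrogen in place of the methyl, would help to settle. Also open, from the compounds shown here alone, is how an ethyl group or an amine on that same aromatic carbon would read in this assay.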